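Amine chain exchange on compound 1: expected step

A few compounds are considered here, and "the series" means these few. Any claim that something is new, unique, unknown or untested is made for them only; others in the source may bear on it.

Values in a functional assay on PC-3 cells (Homo sapiens) for antiproliferative activity, read by MTT assay, with a stated time of 48 h (a lower number here means a stronger inhibitor, a higher number a weaker inhibitor), for the measured compounds:
- compound 1 `COc1cc(C(=O)/C=C/c2ccc(OCCCC(=O)NCCCCN(CCCN)CCCCN)cc2)cc(OC)c1OC` gives 55400 nM
- compound 2 `COc1ccc(/C=C/C(=O)c2cc(OC)c(OC)c(OC)c2)cc1OCCCC(=O)NCCCNCCCCNCCN` gives 31800 nM
- compound 3 `COc1ccc(/C=C/C(=O)c2cc(OC)c(OC)c(OC)c2)cc1OCCCC(=O)NCCCCN(CCCN)CCCCN` gives 60600 nM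

All three values lie within the scatter of one another, so compound 1 (55400 nM) stands level with compound 2 and compound 3, and no order can be read among them.

Compound 4 `COc1cc(C(=O)/C=C/c2ccc(OCCCC(=O)NCCCNCCCCNCCN)cc2)cc(OC)c1OC` keeps the core of compound 1 and carries (4-((2-aminoethyl)amino)butyl)amino in place of ((4-aminobutyl)(3-aminopropyl)amino)methyl on a saturated chain carbon, three bonds along the chain from an amide-type nitrogen.

Among the measured compounds shown here, the only measured step bearing on this is the same exchange, run in the opposite direction on a related core: a 1.9-fold higher number from compound 2 to compound 3 (0.28 log units; within the scatter). Read backwards, it points to a lower number, but it stays within the scatter, so no step beyond the scatter is expected in this assay. The estimated change is a 1.5-fold lower number from compound 1 to compound 4 (0.19 log units; within the scatter). For compound 4 the expected value is 36000 nM, with an estimated range from 19000 nM to 62000 nM.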

Compound 4, half-maximal inhibitory concentration: 34000 nM
Beside the measured number, compound 4's estimate is 1.1-fold (0.02 log units) above it, within the range that was stated.
By their numbers in this assay, from the lowest: compounds 2, 4, 1 and 3 (each within the scatter of the next).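

In this assay, (4-((2-aminoethyl)amino)butyl)amino in place of ((4-aminobutyl)(3-aminopropyl)amino)methyl on a saturated chain carbon, three bonds along the chain from an amide-type nitrogen gives a 1.6-fold lower number from compound 1 to compound 4 (0.21 log units; within the scatter), so this exchange can now be read on a second core. On neither core does the exchange separate the two amine chains beyond the scatter, so at this position the assay does not tell them apart. The two steps also agree in size, though this agreement rests on only two pairs: the same change on two cores in this assay, a 1.9-fold higher number (0.28 log units; within the scatter) from compound 2 to compound 3 and a 1.6-fold higher number (0.21 log units; within the scatter) from compound 4 to compound 1, 1.2-fold (0.07 log units) apart, within the scatter of two such steps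

The compounds shown leave open whether a chain with a single primary amine, or one ending in a carboxylic acid, at this chain carbon would take the number in this assay beyond the scatter. They also leave open whether a longer chain would do so.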